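Thiophen-3-yl for pyridin-4-yl on the shared core

The source may report more compounds than this note shows. Statements on the series, on what has been measured and on what is new or still open speak of the compounds shown alone.

Compound 1 `Oc1cccc(-c2cc(-c3ccncc3)nc(-c3ccccc3Cl)c2)c1` has no result in a functional assay on HCT-15 cells (Homo sapiens) for cytotoxicity, read by CCK-8 assay and cell counting, with a stated time of 2 days; on this read-out higher numbers stand for weaker inhibition and lower numbers for stronger inhibition; compound 1 stands there as "not determined" (no result reported), without a number, so its place in the series rests on the structure alone. Two measured relatives frame the series. Compound 2 `Oc1cccc(-c2cc(-c3ccc(Cl)cc3)nc(-c3ccccn3)c2)c1` gives 13500 nM in this assay. Compound 3 `Oc1cccc(-c2cc(-c3cccc(Cl)c3)nc(-c3cccs3)c2)c1` gives 2610 nM in this assay, a stronger inhibition than compound 2 shows, and the two values lie apart by more than the usual scatter. Within the data shown here, no pair of measured compounds differing in one place is available, so no step size can be read from the data.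

Compound 4 `Oc1cccc(-c2cc(-c3ccsc3)nc(-c3ccccc3Cl)c2)c1` differs from compound 1 in one place: thiophen-3-yl in place of pyridin-4-yl on an aromatic carbon. Compound 1 supplies no value to anchor this change, and the two measured compounds differ from compound 4 in more than one place, so the expected size of the step cannot be given; only the range of the measured values, from compound 2 to compound 3, offers a guide.

Compound 4 is estimated at 4000 nM in this assay, with a range from 1000 nM to 15000 nM.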

Compound 4, half-maximal inhibitory concentration: 2500 nM
Compound 4: the middle estimate sits 1.6-fold (0.20 log units) above what was measured; low and high end bracket the measured number.
By their numbers in this assay, from the lowest: compounds 4 and 3 (each within the scatter of the next); then compound 2.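

No new step can be read for compound 4: compound 1 carries no number to compare with, and compounds 2 and 3 differ from compound 4 in more than one place. As far as these compounds go, the size of the change from pyridin-4-yl to thiophen-3-yl on the shared core stays open. No measured evidence bears on this result.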